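The compounds below may be only part of what the source reports. "The series", "measured", "known", "first", "only" and "open" are said of these compounds alone.

Measured compounds in an assay on cells for agonist activity at vitamin D3 receptor (Homo sapiens), read by microscopy; a higher number here means that more compound is needed for the effect, a lower number that less compound is needed:
compound 1 `CCCCC(=O)c1ccc(C(CC)(CC)c2ccc(C#CC(O)(CC)CC)c(C)c2)n1CC`: > 50 nM
compound 2 `CCn1c(C(=O)NCCC(=O)O)ccc1C(CC)(CC)c1ccc(C#CC(O)(CC)CC)c(C)c1`: 293 nM
compound 3 `CCn1cc(C(CC)(CC)c2ccc(C#CC(O)(CC)CC)c(C)c2)cc1C(=O)OCCO`: 12.6 nM

The value of compound 1 is a limit of this assay, not a number. Among the measured compounds shown here, compound 3 holds the lowest of the two numbers; compound 2 stands a step that the limit leaves unreadable from compound 1 to compound 2 cannot be read in size, as the limit of > 50 nM in this assay, at which 1 of the 3 values shown sits, shows, so the only measured step gives no usable magnitude. Between compound 2 and compound 3, which are not a single-point pair, the values differ by more than the usual scatter, with compound 3 lower.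

Compound 4 `CCn1cc(C(CC)(CC)c2ccc(C#CC(O)(CC)CC)c(C)c2)cc1C(=O)N[C@@H](C(=O)O)C(C)C` differs from compound 3 in (1-carboxy-2-methylpropyl)amino in place of 2-hydroxyethoxy on a carbonyl carbon. The entering group carries a carboxylic acid on an amide, as does compound 2, whose value in this assay is the higher of the two numbers; the leaving group is the ester that compound 3 carries. For the measured compounds named here, no measured step covers this exact change. On this basis a moderate rise in concentration is expected for compound 4, a 4.0-fold higher number from compound 3 to compound 4 (0.60 log units; beyond the scatter), though the scatter of the comparison is wide. Compound 4 is therefore estimated at 50 nM, within 12 nM to 200 nM.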

Compound 4, half-maximal effective concentration: 68.3 nM
Beside the measured number, compound 4's estimate is 1.4-fold (0.14 log units) below it; the range from low to high includes it.
By their numbers in this assay, from the lowest: compound 3; then compound 4; then compound 2.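

In this assay, the change on this carbonyl carbon now has a readable size: (1-carboxy-2-methylpropyl)amino in place of 2-hydroxyethoxy gives a 5.4-fold higher number from compound 3 to compound 4 (0.73 log units; beyond the scatter). Among the compounds shown here, the only earlier step on such a carbonyl carbon cannot be read, so this is the first size available for a change at this kind of place. The step is modest, and compound 4, with its carboxylic acid on an amide, still gives a numerical value of 68.3 nM rather than a limit.

The compounds shown do not separate the exchange of ester for amide from the entry of the carboxylic acid and the branched chain; 2-hydroxyethylamino or (carboxymethyl)amino on the same carbonyl carbon would bear on that. The role of the defined stereocentre also stays open, as its mirror-image counterpart is not among the compounds shown.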